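Replacing 4-butylpiperazin-1-yl with dimethylamino on a shared core

The source may hold more compounds than are shown below. What is called first, only, known or untested is meant among the compounds shown, and "the series" means these compounds.

Of the compounds shown here, three built on one shared core have been measured in a toxicity assay on L02 cells (Homo sapiens) for cytotoxicity, read by MTT assay, with a stated time of 72 h; on this read-out lower numbers stand for stronger inhibition and higher numbers for weaker inhibition. Compound 1 `O=C1c2c[n+]([O-])c3ccccc3c2C(=O)c2c1c1ccccc1n2Cc1cn([C@H]2O[C@H](CO)[C@@H](O)[C@H]2O)nn1` gives 950 nM, and compound 3 `CC1(C)OC[C@@H](Cn2cc(Cn3c4c(c5ccccc53)C(=O)c3c[n+]([O-])c5ccccc5c3C4=O)nn2)O1` gives 2900 nM. Compound 2 `CCCCN1CCN(CCCCn2c3c(c4ccccc42)C(=O)c2c[n+]([O-])c4ccccc4c2C3=O)CC1` gives 5690 nM. This value lies within the usual scatter of compound 3 and clearly beyond the scatter of compound 1.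

Compound 4 `CN(C)CCCCn1c2c(c3ccccc31)C(=O)c1c[n+]([O-])c3ccccc3c1C2=O` has not yet been measured. It differs from compound 2 in one place, on a saturated chain carbon, four bonds along the chain from an aromatic nitrogen: dimethylamino in place of 4-butylpiperazin-1-yl on a saturated chain carbon, four bonds along the chain from an aromatic nitrogen. In short, dimethylamino stands in place of 4-butylpiperazin-1-yl.

Among the compounds with values here, no measured step covers this exact change. The only one available, a 3.1-fold higher number from compound 1 to compound 3 (0.48 log units; beyond the scatter), swaps a different group on an aromatic nitrogen, so it offers a rough guide to size and nothing more. It suggests that replacing one side group on this core can produce a modest shift. Within the data shown here, the direction is tentative: compound 1, at 950 nM, shows only that this core can reach lower numbers than compound 2 does.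

In this assay, the expected change is a 2.3-fold lower number from compound 2 to compound 4 (0.36 log units; beyond the scatter), a modest step towards a lower number. For compound 4 the estimate is 2500 nM, with an expected range from 800 nM to 8000 nM.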

Compound 4, half-maximal inhibitory concentration: 300 nM
Estimate against measurement, compound 4: 8.3-fold (0.92 log units) above, outside the stated range (below it).
By their numbers in this assay, from the lowest: compound 4; then compound 1; then compounds 3 and 2 (each within the scatter of the next).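

In this assay, the group on the saturated chain carbon, four bonds along the chain from an aromatic nitrogen, matters a great deal: putting dimethylamino in place of 4-butylpiperazin-1-yl gives a 19-fold lower number from compound 2 to compound 4 (1.28 log units; beyond the scatter), a large step. Within the data shown here, the earlier compounds offered no one-place comparison at this position, and the only earlier step, a 3.1-fold higher number from compound 1 to compound 3 (0.48 log units; beyond the scatter), sits at a different place and is modest, so this is the first sign that the end of this chain can move the number strongly, here towards more harm to these cells. Nothing measured alongside these values accounts for the drop.

This single swap removes the ring, the second nitrogen and the butyl tail together, so the compounds shown cannot say which of these changes carries the effect; diethylamino, pyrrolidin-1-yl or 4-methylpiperazin-1-yl at the same place would begin to separate them. Among these compounds, it also stays open whether dimethylamino would have a similar effect on a shorter or longer chain, since only this one chain length appears here.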